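Propyl in place of bromophenyl on the ether oxygen

A few compounds are considered here, and "the series" means these few. Any claim that something is new, unique, unknown or untested is made for them only; others in the source may bear on it.

Of the compounds shown here, three built on one shared core have been tested in a functional assay on PC-3 cells (Homo sapiens) for inhibition, read by sulforhodamine B assay, with a stated time of 48 h, tested at 50 uM; on this read-out higher numbers stand for more inhibition of growth at the one concentration tested and lower numbers for less inhibition of growth. Compound 1 `COc1ccc([C@@H]2CC(=O)c3cc(CC=C(C)C)c(OC)cc3O2)cc1` gives 58%. In this assay compound 2 `C#CCOc1ccc([C@@H]2CC(=O)c3cc(CC=C(C)C)c(OC)cc3O2)cc1` gives 52%. In this assay compound 3 `COc1cc2c(cc1CC=C(C)C)C(=O)C[C@@H](c1ccc(Oc3ccc(Br)cc3)cc1)O2` gives 55%. Among these three numbers compound 3 stands with compound 1 nearest and compound 2 furthest, and every gap between the three lies within the usual scatter, so none of them can be called more or less active than another.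

Compound 4 `CCCOc1ccc([C@@H]2CC(=O)c3cc(CC=C(C)C)c(OC)cc3O2)cc1` differs from compound 3 in one place: propyl in place of 4-bromophenyl on an oxygen on an aromatic ring. Going by the values given here, three measured steps touch this same oxygen on an aromatic ring. Exchanging hydrogen for ethynyl on the chain carbon bound to that oxygen gave a number 6 percentage points lower from compound 1 to compound 2 (within the scatter). Exchanging methyl for 4-bromophenyl gave a number 3 percentage points lower from compound 1 to compound 3 (within the scatter), and exchanging propargyl for 4-bromophenyl gave a number 3 percentage points higher from compound 2 to compound 3 (within the scatter). Small, medium and large groups on this oxygen have thus all given numbers inside the scatter of one another, and propyl falls within that span of sizes.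

Compound 4 is therefore expected to give 54%, with a likely range from 42% to 66%. The expected change, a number 1 percentage points lower from compound 3 to compound 4 (within the scatter), is estimated to stay within the scatter.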

Compound 4, percent growth inhibition at one concentration: 54%
For compound 4 middle estimate and measured number coincide at the digits printed; the range from low to high includes it.
By their numbers in this assay, from the lowest: compounds 2, 4, 3 and 1 (each within the scatter of the next).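

In this assay, putting a plain propyl chain on the oxygen in place of 4-bromophenyl takes away a whole six-membered aromatic ring, yet the step reads a number 1 percentage points lower from compound 3 to compound 4 (within the scatter) and the number does not separate from that of the larger group. The same holds against the smaller groups, with ethyl in place of ethynyl giving a number 2 percentage points higher from compound 2 to compound 4 (within the scatter) and ethyl in place of hydrogen giving a number 4 percentage points lower from compound 1 to compound 4 (within the scatter), so this is the first saturated chain longer than methyl on this oxygen, and all four groups shown here, with or without a ring or a triple bond, stay within the scatter of one another. Nothing available here accounts for this flat picture.

From the compounds shown here alone, whether a propyl chain carrying an amine or a carboxylic acid, or a much longer chain such as octyl, would move the number beyond the scatter stays open. All four numbers also come from a single tested concentration, so they leave open whether these compounds would separate at other concentrations.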